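The compounds below may be only part of what the source reports. "The series", "measured", "known", "first", "only" and "open" are said of these compounds alone.

Measured so far in an ADME assay on HEL cells (Homo sapiens) for cytotoxicity, with a stated time of 3 days; on this read-out lower numbers stand for higher toxicity in this test and higher numbers for lower toxicity in this test:
compound 1 `CCC1(Cc2ccccc2)OS(=O)(=O)C=C1OCC(=O)OC`: > 200000 nM
compound 2 `CC1(C(c2ccccc2)c2ccccc2)OS(=O)(=O)C=C1OCc1ccccc1`: 200000 nM

Compound 1 stands at the limit of this assay. Its result is a limit of the test and not a number, as shown by the limit of > 200000 nM in this assay, at which 1 of the 2 values shown sits. Compound 2 gives a number that sits at the same value, so both compounds occupy the low-toxicity end of what this assay reports, and their two values show no difference beyond the scatter.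

As far as these compounds go, the next compound, compound 3 `CCC1(Cc2ccccc2)OS(=O)(=O)C=C1OCCCc1ccccc1`, is untested. It differs from compound 1 in one place: phenethyl in place of methoxycarbonyl on a saturated chain carbon bound to an oxygen on an unsaturated carbon. Phenethyl thus takes the place of methoxycarbonyl on the saturated chain carbon bound to an oxygen on an unsaturated carbon, while the rest of the core of compound 1 is kept.

For the measured compounds named here, no step between measured compounds exists to calibrate this change. With both measured compounds at the limit, the expectation for this assay is no step beyond the scatter. Compound 3 is expected to give 200000 nM, with a range from 100000 nM to 400000 nM. The expected step of a number no higher from compound 1 to compound 3 (the limit leaves the size open) is therefore estimated to lie within the scatter, and a limit result is the likely outcome.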

Compound 3, half-maximal cytotoxic concentration: 133000 nM
Beside the measured number, compound 3's estimate is 1.5-fold (0.18 log units) above it, and the stated range covers the measured number.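

In this assay, phenethyl in place of methoxycarbonyl on the saturated chain carbon bound to an oxygen on an unsaturated carbon gives an at least 1.5-fold lower number from compound 1 to compound 3 (0.17 log units; that floor lies within the scatter). The result for compound 1 is a limit of the test and not a number, so only a floor can be read for this change: the limit of > 200000 nM in this assay, at which 1 of the 3 values shown sits. This position accepts an exchange that removes the two hydrogen-bond acceptors of methoxycarbonyl and brings in a six-membered aromatic ring of carbon only, and compound 3 gives 133000 nM, a measured number on the core of compound 1. The floor of the step does not pass the scatter.

For the compounds shown here, whether the real step from the limit of compound 1 goes beyond the scatter stays open, and the single pair gives no trend for this position. Also open, as far as these compounds go, is how a carboxylic acid, an amine or a longer chain of carbon atoms without the aromatic ring would read in this assay at this place, and whether phenethyl would give a similar result on a core other than that of compound 1.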